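Amino to methoxy on the shared core of compound 2

The compounds below may be only part of what the source reports. "The series", "measured", "known", "first", "only" and "open" are said of these compounds alone.

Compound 2 `Nc1nc(N)c2nc(O)n(Cc3ccccc3)c2n1` stands highest of the two numbers measured in a functional assay (spleen, spleen) for activation, with Mus musculus as the target (a higher number here means that more compound is needed for the effect, a lower number that less compound is needed), where compound 2 gives 10 uM. Its nearest neighbour is compound 1 `CCCCCNc1nc(N)c2nc(O)n(Cc3ccccc3)c2n1`, which in this assay gives 0.1 uM. Among the measured compounds shown here, the one step between measured compounds is a 100-fold higher number from compound 1 to compound 2 (2.00 log units; beyond the scatter), a change described as hydrogen in place of pentyl on a nitrogen on an aromatic ring. Compound 3 `COc1nc(N)c2nc(O)n(Cc3ccccc3)c2n1` is not yet measured; it differs from compound 2 as follows: methoxy in place of amino on an aromatic carbon. For the measured compounds named here, this change touches the same aromatic carbon where the step between compounds 1 and 2 happened, but no measured step swaps amino for methoxy, so the size is uncertain. Going by the values given here, since the only measured step shows that a larger group on this carbon lowered the number, compound 3 is expected to sit somewhat lower than compound 2, by a 3.3-fold lower number from compound 2 to compound 3 (0.52 log units; beyond the scatter). The estimate for compound 3 in this assay is 3 uM, within the range 0.5 uM to 30 uM.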

Compound 3, minimum effective concentration: 0.1 uM
Estimate against measurement, compound 3: 30-fold (1.48 log units) above; the whole stated range lies above it.
By their numbers in this assay, from the lowest: compounds 1 and 3 (each within the scatter of the next); then compound 2.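

The earlier pair left open whether the low number depended on the pentyl chain. On this aromatic carbon, between two ring nitrogen atoms, methoxy in place of amino gives a 100-fold lower number from compound 2 to compound 3 (2.00 log units; beyond the scatter) in this assay and thus reaches the low number without that chain. Methoxy in place of pentylamino gives no change at the digits printed from compound 1 to compound 3 (within the scatter) so the two groups cannot be told apart here, and neither a nitrogen on this carbon nor a hydrogen-bond donor in the group is required for the low number in these compounds.

Going by these compounds, whether methylamino or a longer ether chain such as pentyloxy would also keep the number low remains open. No supporting measurement is available to explain why plain amino stands apart from the other two groups.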